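The source may hold more compounds than are shown below. What is called first, only, known or untested is meant among the compounds shown, and "the series" means these compounds.

Measured compounds:
compound 1 `CN(C(=O)NC(=O)c1c(F)cccc1F)c1nc(C(F)(F)F)c(C(=O)N/N=C/c2cccc(C(F)(F)F)c2)s1` gives 21.6 ug/mL
compound 2 `CN(C(=O)NC(=O)c1ccccc1F)c1nc(C(F)(F)F)c(C(=O)N/N=C/c2cc(C(F)(F)F)cc(C(F)(F)F)c2)s1` gives 4.98 ug/mL
compound 3 `CN(C(=O)NC(=O)c1ccc(Cl)c(Cl)c1)c1nc(C(F)(F)F)c(C(=O)N/N=C/c2ccc([N+](=O)[O-])cc2)s1` gives 5.12 ug/mL

All three numbers come from a functional assay on HeLa cells (Homo sapiens) for inhibition, read by MTT assay, with a stated time of 72 h; a lower number here means a stronger inhibitor, a higher number a weaker inhibitor. Compound 2 and compound 3 sit within the usual scatter of each other, so no order can be read between them. Compound 1 stands apart: its number is higher than that of compound 2 by a gap beyond the scatter, and it also differs from compound 2 in more than one place, so the gap cannot be tied to a single change.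

Compound 4 `CN(C(=O)NC(=O)c1ccc(C(F)(F)F)cc1)c1nc(C(F)(F)F)c(C(=O)N/N=C/c2cc(C(F)(F)F)cc(C(F)(F)F)c2)s1` has not been measured. It differs from compound 2 only by 4-(trifluoromethyl)phenyl in place of 2-fluorophenyl on a carbonyl carbon. Among the measured compounds shown here, no pair among the measured compounds isolates this change; compound 1 and compound 3 each carry a different acyl group together with a different hydrazone, so they cannot serve as a guide for this one step.

With nothing in this assay bearing on the acyl group alone, the expectation for compound 4 is a step of a 1.1-fold higher number from compound 2 to compound 4 (0.04 log units; within the scatter) from compound 2, not beyond the scatter. Compound 4 is therefore estimated at 5.5 ug/mL, with a range from 2 ug/mL to 15 ug/mL.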

Compound 4, half-maximal inhibitory concentration: 5.78 ug/mL
For compound 4 the middle estimate is 1.1-fold (0.02 log units) below the measured one; measured number inside the range.
By their numbers in this assay, from the lowest: compounds 2, 3 and 4 (each within the scatter of the next); then compound 1.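

In this assay, the acyl position now has its first single-change comparison: 4-(trifluoromethyl)phenyl in place of 2-fluorophenyl on a carbonyl carbon gives a 1.2-fold higher number from compound 2 to compound 4 (0.06 log units; within the scatter). At this position, then, the two substituted phenyl groups cannot be told apart, although the entering group carries more heavy atoms and its fluorines sit in a trifluoromethyl group. No measurement shown here offers an explanation for this result.

On these data alone, whether the position holds up with anything other than a fluorinated phenyl group, such as a carboxylic acid or an amine on that ring, or a cyclohexyl group in its place, remains open. The higher number of compound 1, 21.6 ug/mL, also stays untied to any single change, as its acyl group and hydrazone both differ from those of compound 2.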